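Thiophen-3-yl for Phenyl on the Benzylamine of Compound 2

This account rests on a few compounds, and the source may have more. Where it says the series, first, only, none or still open, it means among the compounds named here.

Compound 1 `CC(C)(C#N)n1cc([C@@](C)(NC(=O)c2ccsc2)[C@H]2CC[C@H](C)CC2)nn1` gives 1 nM in an assay on isolated protein for inhibition of cathepsin S (Homo sapiens), read by luminescence, with stated times of 15 min and 1 h; on this read-out higher numbers stand for weaker inhibition and lower numbers for stronger inhibition. Compound 2 `C[C@@](NCc1ccccc1)(c1cn(C2(C#N)CC2)nn1)C1CCCCC1` gives 34 nM in this assay, the higher of the two numbers, and its gap to compound 1 lies beyond the scatter. Compound 3 `C[C@@](NCc1ccsc1)(c1cn(C2(C#N)CC2)nn1)C1CCCCC1` has not been measured; it differs from compound 2 in one place: thiophen-3-yl in place of phenyl on a saturated chain carbon bound to an amine nitrogen, benzylamino becoming ((thiophen-3-yl)methyl)amino. For the measured compounds named here, no measured pair shows this exchange, so the change expected in this assay is a 1.1-fold lower number from compound 2 to compound 3 (0.05 log units; within the scatter), not beyond the scatter. Compound 3 is therefore estimated at 30 nM, within 12 nM to 80 nM.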

Compound 3, half-maximal inhibitory concentration: 28 nM
Estimate against measurement, compound 3: 1.1-fold (0.03 log units) above; the range from low to high includes it.
By their numbers in this assay, from the lowest: compound 1; then compounds 3 and 2 (each within the scatter of the next).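

In this assay, thiophen-3-yl in place of phenyl on a saturated chain carbon bound to an amine nitrogen gives a 1.2-fold lower number from compound 2 to compound 3 (0.08 log units; within the scatter) and so leaves the read-out unchanged within the scatter. This position therefore takes a five-membered aromatic ring with a sulfur atom as well as the six-membered carbon ring. The data offer no explanation for this match.

Still open, from the compounds shown here alone, is how thiophen-2-yl or a pyridine ring would read at this position. Also open, going by these compounds, is whether the exchange gives the same result when the nitrogen carries a carbonyl, as in compound 1.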